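The source may report more compounds than this note shows. Statements on the series, on what has been measured and on what is new or still open speak of the compounds shown alone.

Of the compounds shown here, two built on one shared core have so far been tested in an assay on microsomes from brain for inhibition of Fatty-acid amide hydrolase 1 (Rattus norvegicus), read by fluorescence and HPLC, with a stated time of 60 min; on this read-out higher numbers stand for weaker inhibition and lower numbers for stronger inhibition. Compound 1 `CCCCCCCCc1ccc(OCC(=O)Cn2nnnc2-c2ccc(S(=O)(=O)N(C)C)cc2)cc1` gives 1400 nM in this assay, while compound 2 `CCCCCCCCc1ccc(OCC(=O)Cn2nnnc2-c2ccncc2)cc1` gives 190 nM. Among the measured compounds shown here, compound 2 therefore holds the lower of the two numbers, and the single step between them, a 7.4-fold lower number from compound 1 to compound 2 (0.87 log units; beyond the scatter), shows that changing the aryl group attached to the five-membered ring moves the read-out by a modest but real amount. Compound 3 `CCCCCCCCc1ccc(OCC(=O)Cn2nnnc2-c2ccc(C(=O)O)cc2)cc1` has not yet been measured. It differs from compound 2 by 4-carboxyphenyl in place of pyridin-4-yl on an aromatic carbon. For the measured compounds named here, the only step that bears on this change is the one from compound 1 to compound 2, which also exchanged one aryl group for another at the same place and was modest in size. A step of roughly that size is therefore expected here, and a rise in the number is thought somewhat more likely than a fall, because compound 1 1400 nM carried a carbon-only ring with a substituent at its far end and gave the higher number. The step expected from compound 2 to compound 3 is an 11-fold higher number from compound 2 to compound 3 (1.02 log units; beyond the scatter). Compound 3 is estimated at 2000 nM, with a range from 400 nM to 10000 nM.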

Compound 3, half-maximal inhibitory concentration: 3400 nM
Compound 3: the middle estimate sits 1.7-fold (0.23 log units) below what was measured, and the stated range covers the measured number.
By their numbers in this assay, from the lowest: compound 2; then compound 1; then compound 3.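

In this assay, the exchange of pyridin-4-yl for 4-carboxyphenyl gives a large step (an 18-fold higher number from compound 2 to compound 3 (1.25 log units; beyond the scatter)), so the number at this aromatic carbon is now seen to rise with two different substituted carbon-only rings, and neither of them matches compound 2. The two substituted rings also differ from each other, as carboxy in place of dimethylsulfamoyl gives a modest step (a 2.4-fold higher number from compound 1 to compound 3 (0.39 log units; beyond the scatter)), so the group carried on the carbon-only ring changes the read-out as well. No measurement shown here accounts for either step.

Compound 1 and compound 3 differ from compound 2 both in having a carbon-only ring and in carrying an added group, so the three compounds cannot show which of these two differences goes with the higher numbers; an unsubstituted phenyl ring, or a pyridine ring bearing a carboxylic acid, would pull them apart. Also open, as far as these compounds go, is how the number would respond to a methyl ester or a primary amide in place of the carboxy group.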